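Ether in place of ester on a naphthoquinone side chain

This account rests on a few compounds, and the source may have more. Where it says the series, first, only, none or still open, it means among the compounds named here.

Three compounds share a core and differ only in the group on an oxygen on a saturated carbon. Compound 1 `CC(C)=CC[C@@H](OC(=O)C1CCOC1)C1=CC(=O)c2c(O)ccc(O)c2C1=O` gives 73500 nM in a functional assay on HeLa cells (Homo sapiens) for cytotoxicity, read by MTT assay (a lower number here means a stronger inhibitor, a higher number a weaker inhibitor), the highest of the three numbers. Compound 2 `CCCC(O)CC(=O)O[C@H](CC=C(C)C)C1=CC(=O)c2c(O)ccc(O)c2C1=O` gives 59300 nM, a change of a 1.2-fold lower number from compound 1 to compound 2 (0.09 log units; within the scatter). Compound 3 `CC(C)=CC[C@@H](OCCO)C1=CC(=O)c2c(O)ccc(O)c2C1=O` gives 18600 nM, a step of a 4.0-fold lower number from compound 1 to compound 3 (0.60 log units; beyond the scatter) and, from the ester of compound 2, a 3.2-fold lower number from compound 2 to compound 3 (0.50 log units; beyond the scatter).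

Compound 4 `CC(C)=CC[C@@H](OCC(C)O)C1=CC(=O)c2c(O)ccc(O)c2C1=O` has not yet been measured. Its difference from compound 1 is 2-hydroxypropyl in place of (oxolan-3-yl)carbonyl on an oxygen on a saturated carbon. The two measured steps that replace a carbonyl-linked group with a short hydroxyalkyl group both gave modest decreases beyond the scatter, and compound 4 carries a 2-hydroxypropyl group that differs from the 2-hydroxyethyl of compound 3 only by one carbon. Compound 4 is therefore expected to show a step of a 3.7-fold lower number from compound 1 to compound 4 (0.57 log units; beyond the scatter), landing close to compound 3. The estimate for compound 4 in this assay is 20000 nM, with a range from 8000 nM to 50000 nM.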

Compound 4, half-maximal inhibitory concentration: 24700 nM
Compound 4: the middle estimate sits 1.2-fold (0.09 log units) below what was measured; measured number inside the range.
By their numbers in this assay, from the lowest: compounds 3 and 4 (each within the scatter of the next); then compounds 2 and 1 (each within the scatter of the next).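

In this assay, a second ether now lies beyond the scatter below both esters (a 3.0-fold lower number from compound 1 to compound 4 (0.47 log units; beyond the scatter); a 2.4-fold lower number from compound 2 to compound 4 (0.38 log units; beyond the scatter)), so the lower number at this oxygen is not confined to the 2-hydroxyethyl group of compound 3. The added methyl on the ether chain gives a step within the scatter (a 1.3-fold higher number from compound 3 to compound 4 (0.12 log units; within the scatter)), and compound 3 and compound 4 cannot be told apart here. Nothing measured here explains why these two ethers give lower numbers than the two esters.

On these data alone, it remains open whether the hydroxyl on the chain matters, as a plain ethyl ether would show. Also open, as far as these compounds go, is how an ether ending in an amine or a carboxylic acid, or one with a longer chain than 2-hydroxypropyl, would behave at this oxygen.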